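Boronic acid in place of methoxy on a fluorophenyl chalcone

The compounds below may be only part of what the source reports. "The series", "measured", "known", "first", "only" and "open" are said of these compounds alone.

Measured compounds:
compound 1, `COc1ccc(/C=C/C(=O)c2ccccc2-c2ccc(OC)c(OC)c2)cc1OC`: 8500 nM
compound 2, `COc1ccc(/C=C/C(=O)c2ccccc2-c2ccc(F)cc2)cc1OC`: 440 nM

In a functional assay on A549 cells (Homo sapiens) for antiproliferative activity, read by sulforhodamine B assay, with a stated time of 48 h (on this read-out lower numbers stand for stronger inhibition and higher numbers for weaker inhibition), compound 1 gives 8500 nM and compound 2 gives 440 nM. Among the compounds with values here, the single measured step, a 19-fold lower number from compound 1 to compound 2 (1.29 log units; beyond the scatter), lies on the ring attached to the core and leaves the dimethoxy-bearing ring untouched. Compound 2 therefore holds the lowest number of the two, with compound 1 far behind.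

Compound 3, `COc1ccc(/C=C/C(=O)c2ccccc2-c2ccc(F)cc2)cc1B(O)O`, differs from compound 2 by a group of 3 heavy atoms (1 boron, 2 oxygen; no ring) in place of a group of 2 heavy atoms (1 carbon, 1 oxygen; no ring), on an aromatic carbon. Within the data shown here, no measured step touches this ring, so the one known step gives no direct guide to the size or direction of the change. With that gap in the data, a modest weakening is expected, roughly a 3.4-fold higher number from compound 2 to compound 3 (0.53 log units; beyond the scatter), though a result within the scatter is also plausible. The estimate for compound 3 in this assay is 1500 nM, in the range 300 nM to 8000 nM.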

Compound 3, half-maximal inhibitory concentration: 82 nM
Beside the measured number, compound 3's estimate is 18-fold (1.26 log units) above it, outside the stated range (below it).
By their numbers in this assay, from the lowest: compound 3; then compound 2; then compound 1.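

In this assay, the only change shown at this aromatic carbon, ortho to a methoxy group and meta to a large group, gives a 5.4-fold lower number from compound 2 to compound 3 (0.73 log units; beyond the scatter). Methoxy is therefore not needed here for activity when the 4-fluorophenyl group is present, and this place accepts a boronic acid with 2 hydrogen-bond donors where methoxy has 0, whereas the earlier step spoke only to the other ring. Nothing available bears on why the number falls.

The compounds shown leave open whether the boronic acid itself matters or whether removing methoxy is enough, a question that a plain hydrogen, a hydroxyl, an amine or a carboxylic acid at this carbon would help to settle. Also open, as far as these compounds go, is whether the same exchange would carry over to compound 1, with its 3,4-dimethoxyphenyl group.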